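This account rests on a few compounds, and the source may have more. Where it says the series, first, only, none or still open, it means among the compounds named here.

In an ADME assay on microsomes from liver (Mus musculus, strain ICR) for metabolic stability, read by LC-MS, using NADPH, with a stated time of 60 min, tested at 0.1 uM (on this read-out lower numbers stand for a less stable compound and higher numbers for a more stable compound), compound 2 `CC#CCn1c(N2CCC[C@@H](N)C2)cc(=O)n(Cc2ccc(F)c(C(=O)OC)c2)c1=O` gives 56%. Within the data shown here, this is the lower of the two numbers measured so far, and it lies beyond the usual scatter from compound 1 `CC#CCn1c(N2CCC[C@@H](N)C2)cc(=O)n(Cc2ccc(Cl)c(C(=O)O)c2)c1=O`, which gives 70.7%. Compound 3 `CC#CCn1c(N2CCC[C@@H](N)C2)cc(=O)n(Cc2ccc(F)c(C(=O)O)c2)c1=O` differs from compound 2 in one place: hydrogen in place of methyl on an oxygen next to a carbonyl group. Hydrogen stands in place of methyl on an oxygen next to a carbonyl group, turning methoxycarbonyl into carboxy. Among the measured compounds shown here, no two measured compounds differ in just one place, so this change has no direct precedent here. For the measured compounds named here, the only measured compound with a carboxy group is compound 1, at 70.7%, which makes it a loose guide and no more. A moderate rise, somewhat beyond the scatter, is expected, a number 16 percentage points higher from compound 2 to compound 3 (beyond the scatter). Compound 3 is estimated at 72%, with an expected range from 58% to 87%.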

Compound 3, percent of the compound remaining: 37.5%
Estimate against measurement, compound 3: 34.5 percentage points above; the whole stated range lies above it.
By their numbers in this assay, from the lowest: compound 3; then compound 2; then compound 1.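

In this assay, among these compounds, turning methoxycarbonyl into carboxy gives a number 18.5 percentage points lower from compound 2 to compound 3 (beyond the scatter), so a free carboxy group does not by itself bring a high number, as the single earlier carboxy compound might have suggested. With the carboxy group kept in place, fluoro in place of chloro on an aromatic carbon gives a number 33.2 percentage points lower from compound 1 to compound 3 (beyond the scatter), which shows that the halogen on the aromatic ring strongly shapes the result, even though it is a small change. Nothing measured here explains either fall.

As far as these compounds go, it remains open whether the change from methoxycarbonyl to carboxy would also lower the number in a compound carrying chloro. It is also unknown how a bromo group in place of the halogen, or an amide or ethyl ester in place of the carboxy group, would read in this assay.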